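Para-Methoxyphenyl Analogue in a Weakly Antiproliferative Series

The source may hold more compounds than are shown below. What is called first, only, known or untested is meant among the compounds shown, and "the series" means these compounds.

Compound 1 `CC(C)N1C(=O)COc2ccc(-c3cccc(NS(=O)(=O)c4ccc(F)cc4)c3)cc21`: 26000 nM
Compound 2 `O=C1COc2ccc(-c3cccc(NS(=O)(=O)c4ccc(F)cc4)c3)cc2N1c1ccc(Cl)cc1`: 39800 nM
Compound 3 `O=C1COc2ccc(-c3cccc(NS(=O)(=O)c4ccc(F)cc4)c3)cc2N1c1ccc(F)cc1`: > 40000 nM

In a functional assay on MCF7 cells (Homo sapiens) for antiproliferative activity, read by MTT assay, with a stated time of 72 h (on this read-out lower numbers stand for stronger inhibition and higher numbers for weaker inhibition), compound 1 gives 26000 nM and compound 2 gives 39800 nM. For compound 3 this assay reports only a limit, > 40000 nM. Compound 3 thus stands at the limit of > 40000 nM in this assay, at which 1 of the 3 values shown sits, and a number no lower from compound 2 to compound 3 (the limit leaves the size open) cannot be sized. Compound 4 `COc1ccc(N2C(=O)COc3ccc(-c4cccc(NS(=O)(=O)c5ccc(F)cc5)c4)cc32)cc1` differs from compound 3 by methoxy in place of fluoro on an aromatic carbon. Among the measured compounds shown here, the steps that bear on this are a 1.5-fold higher number from compound 1 to compound 2 (0.18 log units; within the scatter) and an at least 1.5-fold higher number from compound 1 to compound 3 (0.18 log units; that floor lies within the scatter), both replacing the group on the amide-type nitrogen, and a number no lower from compound 2 to compound 3 (the limit leaves the size open) at the same aromatic carbon; none shows a change beyond the scatter. No change beyond the scatter is therefore expected for compound 4 in this assay. Compound 4 is expected to give about 40000 nM, between 18000 nM and 90000 nM. The expected step is a number no higher from compound 3 to compound 4 (the limit leaves the size open).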

Compound 4, half-maximal inhibitory concentration: 32400 nM
Beside the measured number, compound 4's estimate is 1.2-fold (0.09 log units) above it, within the range that was stated.
By their numbers in this assay, from the lowest: compounds 1, 4 and 2 (each within the scatter of the next). At a limit, above all of these: compound 3.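

With methoxy in place of fluoro on the aromatic carbon para to a large group, this assay gives an at least 1.2-fold lower number from compound 3 to compound 4 (0.09 log units; that floor lies within the scatter). Against the other two groups, the 4-methoxyphenyl compound shows a 1.2-fold lower number from compound 2 to compound 4 (0.09 log units; within the scatter) and a 1.2-fold higher number from compound 1 to compound 4 (0.10 log units; within the scatter), so a group bearing a hydrogen-bond acceptor also produces no change beyond the scatter. The value of compound 3 remains a limit: the limit of > 40000 nM in this assay, at which 1 of the 4 values shown sits.

The compounds shown leave open whether an amine or a carboxylic acid on that aromatic carbon would produce a change beyond the scatter. They also leave open whether a longer chain in place of isopropyl on the amide-type nitrogen would do so.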